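From compound 3 to compound 4: a step off a limit

A few compounds are considered here, and "the series" means these few. Any claim that something is new, unique, unknown or untested is made for them only; others in the source may bear on it.

Compound 3 (`COc1ccc(/C=C/C(=O)c2ccc(OC)c3c2OC(C)(C)C=C3)cn1`) gives > 10000 nM in a functional assay on HT-29 cells (Homo sapiens) for antiproliferative activity, read by MTT assay, with a stated time of 24 h (on this read-out lower numbers stand for stronger inhibition and higher numbers for weaker inhibition), and this is a limit of the assay, not a number. Compound 2 (`COc1ccc(C(=O)/C=C/c2ccc(C(F)(F)F)cc2)c2c1C=CC(C)(C)O2`) gives > 10000 nM as a limit too. Going by the values given here, compound 1 (`COc1ccc(C(=O)/C=C/c2cccc([N+](=O)[O-])c2)c2c1C=CC(C)(C)O2`) gives 4260 nM as the only number in the set. The set is therefore marked by the limit of > 10000 nM in this assay, at which 2 of the 3 values shown sit, and by that single number.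

Compound 4 (`COc1ccc(C(=O)/C=C/c2ccccc2Cl)c2c1C=CC(C)(C)O2`) is reached by 2-chlorophenyl in place of 6-methoxypyridin-3-yl on a double-bonded chain carbon bound to a double-bonded chain carbon with 2-chlorophenyl in place of 6-methoxypyridin-3-yl on a double-bonded chain carbon bound to a double-bonded chain carbon. Among the compounds with values here, the one measured step at this place is an at least 2.3-fold higher number from compound 1 to compound 3 (0.37 log units; beyond the scatter) and it lies beyond the scatter, though its true size stays open. Compound 1 reads 4260 nM, so a modest move toward lower numbers is expected in this assay. Compound 2 gives > 10000 nM, which is a limit, so another limit is expected to remain a real chance for compound 4. The estimate means an at least 1.2-fold lower number from compound 3 to compound 4 (0.09 log units; that floor lies within the scatter) as the expected move. For compound 4 the estimated value is 8000 nM with an expected range from 3000 nM to 20000 nM in this assay.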

Compound 4, half-maximal inhibitory concentration: > 10000 nM
Compound 4: a limit, no number; the forecaster's own chance of this, stated with the estimate: 45%; at least 1.2-fold (0.09 log units) between middle value and limit.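

In this assay, 2-chlorophenyl on a double-bonded chain carbon bound to a double-bonded chain carbon gives no readable number, so this place now holds three groups that end at the limit of the assay. Measured against the one number in the set, the change gives an at least 2.3-fold higher number from compound 1 to compound 4 (0.37 log units; beyond the scatter), which leaves 3-nitrophenyl as the only group shown here that comes off the limit. The step between compound 3 and compound 4 cannot be read, both ends being limits, and the set now rests mostly on a single limit: the limit of > 10000 nM in this assay, at which 3 of the 4 values shown sit.

On these data alone, how compound 2, compound 3 and compound 4 rank among themselves stays open. Also open, as far as these compounds go, is whether an amine or a carboxylic acid on the same ring as in compound 1 would give a number in this assay.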